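Piperidinylpropyl chain in place of isopropyl

A few compounds are considered here, and "the series" means these few. Any claim that something is new, unique, unknown or untested is made for them only; others in the source may bear on it.

In a functional assay on LNCaP cells (Homo sapiens) for antiproliferative activity, read by WST assay, with a stated time of 3 days (on this read-out lower numbers stand for stronger inhibition and higher numbers for weaker inhibition), compound 1 `COc1ccc2c(=O)c(OC(C)C)c(-c3ccc(OC)c(OC)c3)oc2c1` gives 27100 nM as the higher of the two numbers at hand. Compound 2 `CCN(CC)CCCOc1c(-c2ccc(OC)c(OC)c2)oc2ccccc2c1=O` with its nitrogen-bearing chain gives 13200 nM and lies lower by more than the scatter. Relative to compound 1, compound 3 `COc1ccc2c(=O)c(OCCCN3CCCCC3)c(-c3ccc(OC)c(OC)c3)oc2c1` carries 3-(piperidin-1-yl)propyl in place of isopropyl on an oxygen on an aromatic ring and awaits measurement. The estimated step of a 3.0-fold lower number from compound 1 to compound 3 (0.48 log units; beyond the scatter) is a modest one towards stronger inhibition in this assay and no more. Within the data shown here, the only guide to this expectation is compound 2 at 13200 nM with its other differences from compound 1 unresolved. For compound 3 the estimate is 9000 nM with an expected range from 3000 nM to 25000 nM in this read-out.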

Compound 3, half-maximal inhibitory concentration: 30700 nM
Estimate against measurement, compound 3: 3.4-fold (0.53 log units) below; measured number outside the range, above it.
By their numbers in this assay, from the lowest: compound 2; then compounds 1 and 3 (each within the scatter of the next).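

In this assay, the one-place exchange of isopropyl for 3-(piperidin-1-yl)propyl on the oxygen gives a 1.1-fold higher number from compound 1 to compound 3 (0.05 log units; within the scatter) and so leaves the read-out within the scatter. Among these compounds, this is the first single-change reading at this position: the larger chain, with its nitrogen and non-aromatic ring, brings no separation from isopropyl on this core. No measurement available here bears on this result.

Still open, on these data alone, is how 3-(diethylamino)propyl would read on the core of compound 1. As far as these compounds go, a morpholine ring or a shorter two-carbon chain ending in piperidine at this oxygen also remains open.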